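Methoxy for methyl on the shared core: expected effect

This account rests on a few compounds, and the source may have more. Where it says the series, first, only, none or still open, it means among the compounds named here.

The series shares one amide core; compound 1 `O=C(Nc1cccc(I)c1)C(Cl)Cl`, compound 2 `O=C(Nc1cccc(C(F)(F)F)c1)C(Cl)Cl` and compound 3 `Cc1ccc(NC(=O)C(Cl)Cl)cc1` differ only in the group carried on the aromatic ring. In a functional assay on A549 cells (Homo sapiens) for antiproliferative activity, read by MTT assay, with a stated time of 72 h (on this read-out lower numbers stand for stronger inhibition and higher numbers for weaker inhibition), compound 1 gives 4760 nM, compound 2 gives 12200 nM and compound 3 gives 48900 nM. Compound 3 therefore stands highest of the three numbers, beyond the scatter from both compound 1 and compound 2. Among the compounds with values here, the only single-point step measured so far is a 2.6-fold higher number from compound 1 to compound 2 (0.41 log units; beyond the scatter), an exchange between two groups of a different kind that does not involve methyl or methoxy. Compound 4 `COc1ccc(NC(=O)C(Cl)Cl)cc1` arises from compound 3 by methoxy in place of methyl on an aromatic carbon. Within the data shown here, no measured step bears directly on this exchange; the one step available shows only that swapping one small ring substituent for another on this core moved this assay modestly. The expected step is a 1.2-fold lower number from compound 3 to compound 4 (0.09 log units; within the scatter), within the scatter and in no definite direction. Compound 4 is thus estimated at 40000 nM in this assay, with a range from 15000 nM to 110000 nM.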

Compound 4, half-maximal inhibitory concentration: 80900 nM
Beside the measured number, compound 4's estimate is 2.0-fold (0.31 log units) below it, and the stated range covers the measured number.
By their numbers in this assay, from the lowest: compound 1; then compound 2; then compounds 3 and 4 (each within the scatter of the next).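

In this assay, the exchange of methyl for methoxy gives a 1.7-fold higher number from compound 3 to compound 4 (0.22 log units; within the scatter), so this step does not separate the two groups at this position, para to a group of 6 heavy atoms. The added oxygen, counted as 1 hydrogen-bond acceptor, therefore brings no change in this read-out that can be told from the scatter, and compound 4 remains in the same range as compound 3. Within the data shown here, the only earlier step exchanged iodo and trifluoromethyl, so this is the first single-place reading for methyl and methoxy on the shared core, and no available evidence bears on why the two groups read alike.

Still open, as far as these compounds go, is whether an amine or a carboxylic acid on this aromatic carbon would move the number beyond the scatter from compound 3. From the compounds shown here alone, a longer chain, such as ethoxy, at the same place is equally open.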